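Trimethoxyphenyl in Place of Phenylethenyl on the Shared Core

A few compounds are considered here, and "the series" means these few. Any claim that something is new, unique, unknown or untested is made for them only; others in the source may bear on it.

Of the compounds shown here, two with the same core have so far been measured in a functional assay on NCI-H23 cells (Homo sapiens) for antiproliferative activity, with a stated time of 48 h; on this read-out lower numbers stand for stronger inhibition of growth and higher numbers for weaker inhibition of growth. Compound 1 `Cc1cc(O)c(C2=NN(c3ccc(S(N)(=O)=O)cc3)C(c3ccccc3O)C2)cc1Cl` gives 2090 nM, and compound 2 `Cc1cc(O)c(C2=NN(c3ccc(S(N)(=O)=O)cc3)C(/C=C/c3ccccc3)C2)cc1Cl` gives 1680 nM. The step of a 1.2-fold lower number from compound 1 to compound 2 (0.09 log units; within the scatter) is too small to count as a change, so compound 2 holds the lowest of the two numbers only nominally, with compound 1 close beside it. Compound 3 `COc1ccc(C2CC(c3cc(Cl)c(C)cc3O)=NN2c2ccc(S(N)(=O)=O)cc2)c(OC)c1OC` differs from compound 2 in one place: 2,3,4-trimethoxyphenyl in place of 2-phenylethenyl on a saturated ring carbon. For the measured compounds named here, no measured step trades the same pair of groups, and the only step on this carbon, from compound 1 to compound 2, stayed within the scatter. On that basis the step of a 1.1-fold lower number from compound 2 to compound 3 (0.05 log units; within the scatter) is expected to stay within the scatter as well, in no firm direction, though the wide uncertainty is acknowledged. Compound 3 is therefore estimated at 1500 nM in this assay, with a range from 450 nM to 5000 nM.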

Compound 3, concentration for 50% growth inhibition: 2110 nM
The estimate for compound 3 lay 1.4-fold (0.15 log units) below the measured number; the range from low to high includes it.
By their numbers in this assay, from the lowest: compounds 2, 1 and 3 (each within the scatter of the next).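

In this assay the step of a 1.3-fold higher number from compound 2 to compound 3 (0.10 log units; within the scatter) lies within the scatter, and the step of a 1.0-fold higher number from compound 1 to compound 3 (0.00 log units; within the scatter) does too, so 2-hydroxyphenyl, 2-phenylethenyl and 2,3,4-trimethoxyphenyl cannot be told apart on this saturated ring carbon. This adds a sharper contrast than the earlier pair offered: 2,3,4-trimethoxyphenyl has 12 heavy atoms and 3 hydrogen-bond acceptors, against 8 heavy atoms and 0 acceptors for 2-phenylethenyl, yet the read-out shows no real change. No supporting information is available to explain this lack of change.

All three groups carry one six-membered aromatic ring of carbon only, so these compounds cannot show whether the read-out would hold with an amine, a carboxylic acid or a plain longer carbon chain here. Going by these compounds, whether any group on this carbon can shift the number beyond the scatter remains open.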